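Two Chlorines on a Thiophene: Cytotoxicity Outlook

A few compounds are considered here, and "the series" means these few. Any claim that something is new, unique, unknown or untested is made for them only; others in the source may bear on it.

Compound 2 `c1csc(C2=NNC(c3ccc(N4CCCCC4)cc3)C2)c1` and compound 1 `Cc1cc(C(=O)/C=C/c2ccc(N3CCCCC3)cc2)c(C)s1` share part of their structure but differ in several places at once. In an ADME assay on Vero cells (Chlorocebus sabaeus) for cytotoxicity, with a stated time of 5 days (a lower number here means a stronger inhibitor, a higher number a weaker inhibitor), compound 2 gives 3200 nM, the lower of the two numbers, while compound 1 gives 42300 nM, a gap that lies beyond the usual scatter. Because the two compounds differ in more than one place, this gap cannot be tied to any single change. Compound 3 `Clc1cc(C2=NNC(c3ccc(N4CCCCC4)cc3)C2)c(Cl)s1` is a close relative of compound 2 that carries 2,5-dichlorothiophen-3-yl in place of thiophen-2-yl on a carbon with a double bond to nitrogen. Among the compounds with values here, no measured pair shows what such a change does in this assay, so the direction of the step is not known from the data, and a step no larger than the usual scatter, in either direction, is expected. Compound 3 is therefore expected to give about 2500 nM in this assay, within a range from 800 nM to 8000 nM. This amounts to an expected step of a 1.3-fold lower number from compound 2 to compound 3 (0.11 log units; within the scatter).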

Compound 3, half-maximal inhibitory concentration: 53900 nM
For compound 3 the middle estimate is 22-fold (1.33 log units) below the measured one, and the stated range ends below it.
By their numbers in this assay, from the lowest: compound 2; then compounds 1 and 3 (each within the scatter of the next).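

Replacing thiophen-2-yl with 2,5-dichlorothiophen-3-yl on the carbon with a double bond to nitrogen gives, in this assay, a 17-fold higher number from compound 2 to compound 3 (1.23 log units; beyond the scatter), so the number at this position clearly responds to the group it carries. The swap changes both the point of attachment on the thiophene and the presence of chlorine, and this single step cannot separate those two changes. No measurement shown explains why the number rises.

The compounds shown leave open whether a plain thiophen-3-yl group, or a thiophene with only one chlorine, would produce a step of similar size. Going by these compounds, it also remains open how a different kind of group at this position, such as an amine or a phenyl ring, would read in this assay.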